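The source may hold more compounds than are shown below. What is called first, only, known or untested is meant among the compounds shown, and "the series" means these compounds.

In a functional assay on CCRF-CEM cells (Homo sapiens) for antiproliferative activity, read by MTT assay, with a stated time of 48 h (on this read-out lower numbers stand for an effect already at smaller amounts and higher numbers for an effect only at larger amounts of compound), compound 1 `COC(=O)c1[nH]c2cc(OC)ccc2c1-c1ccc(Br)cc1` gives 330 nM. Compound 2 `COC(=O)c1[nH]c2cc(C(F)(F)F)ccc2c1-c1ccc(C(F)(F)F)cc1` gives > 100000 nM, which is a limit. Compound 3 `COC(=O)c1[nH]c2cc(OC)ccc2c1C(C)C` gives > 100000 nM, also only a limit. Compound 4 `COC(=O)c1[nH]c2cc(OC)ccc2c1Cc1ccccc1` carries benzyl in place of isopropyl on an aromatic carbon. Within the data shown here, one measured step bears on this place: an at least 300-fold higher number from compound 1 to compound 3 (2.48 log units; beyond the scatter), a large one, with isopropyl in place of 4-bromophenyl. Benzyl brings a six-membered aromatic ring back, so part of that step may return, though compound 2 also keeps a ring there and sits at its limit. In this assay the expected change, towards a lower number, is an at least 6.6-fold lower number from compound 3 to compound 4 (0.82 log units; beyond the scatter). The estimate for compound 4 is 15000 nM, within an expected range of 1500 nM to 100000 nM.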

Compound 4, half-maximal effective concentration: 8700 nM
For compound 4 the middle estimate is 1.7-fold (0.24 log units) above the measured one; low and high end bracket the measured number.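

In this assay, benzyl at this position gives a measurable number where isopropyl does not, with an at least 11-fold lower number from compound 3 to compound 4 (1.06 log units; beyond the scatter). The recovery is only partial, since 4-bromophenyl remains ahead of benzyl, with a 26-fold higher number from compound 1 to compound 4 (1.42 log units; beyond the scatter); a six-membered aromatic ring at this place is therefore not enough to match compound 1. Compound 3 stands only at a limit, so the first step is a bound and its true size stays unknown: the limit of > 100000 nM in this assay, at which 2 of the 4 values shown sit.

Still open, on these data alone, is whether the gap to compound 1 follows the bromine or the methylene link. Phenyl or 4-bromobenzyl at this place would separate the two.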